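From Iodo to Fluoro on the Shared Core

The source may report more compounds than this note shows. Statements on the series, on what has been measured and on what is new or still open speak of the compounds shown alone.

Of the compounds shown here, two have so far been measured in a functional assay on Raji cells (Homo sapiens); a higher number here means a weaker inhibitor, a lower number a stronger inhibitor. Compound 1, `O=c1[nH]c(=O)n([C@@H]2O[C@H](COP(=O)(O)O)[C@@H](O)[C@H]2O)cc1Br`, gives 48 ug/mL. Compound 2, `O=c1[nH]c(=O)n([C@@H]2O[C@@H]3COP(=O)(O)O[C@H]3[C@H]2O)cc1I`, gives 359 ug/mL. Compound 2 therefore stands at the highest, that is the weakest, of the two numbers, and its gap to compound 1 lies beyond the usual scatter. The two compounds differ in more than one place, however, so no single step can be read off between them.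

Compound 3, `O=c1[nH]c(=O)n([C@@H]2O[C@@H]3COP(=O)(O)O[C@H]3[C@H]2O)cc1F`, is not yet measured. It differs from compound 2 in one place: fluoro in place of iodo on an aromatic carbon.

Without a measured one-place step, the direction of this change rests on weak ground. Compound 1, which carries bromo rather than iodo and gives 48 ug/mL, shows that a smaller group at that carbon can go with a lower number, though it differs elsewhere as well. The step of a 2.4-fold lower number from compound 2 to compound 3 (0.38 log units; beyond the scatter) is expected to be modest, toward a lower number, with wide uncertainty. Compound 3 is estimated at 150 ug/mL in this assay, within a range from 30 ug/mL to 700 ug/mL.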

Compound 3, concentration for 50% inhibition: 0.416 ug/mL
Beside the measured number, compound 3's estimate is 360-fold (2.56 log units) above it; measured number below the stated range.
By their numbers in this assay, from the lowest: compound 3; then compound 1; then compound 2.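

In this assay, among the compounds shown here, this is the first step on the shared core that can be read in one place, and it is large: an 860-fold lower number from compound 2 to compound 3 (2.94 log units; beyond the scatter) comes with fluoro in place of iodo on the aromatic carbon. The change is small on paper, since one heavy atom leaves and one enters, with no ring, no hydrogen-bond donor or acceptor and no net charge on either side. Even so, the identity of this single atom matters greatly for the number read in this assay, so this carbon is a highly sensitive position in this pair. Nothing at hand bears on what lies behind the size of this step.

With only iodo and fluoro compared directly on this core, two points do not show whether the numbers follow a gradual trend or whether fluoro is a special case, and a hydrogen, a chloro or a methyl at the same carbon would be needed to tell. Going by these compounds, it also remains open whether fluoro in place of another group at this carbon would bring a similar drop on the core of compound 1.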